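Moving the halogen on the anilino ring of a bicyclic amine

A few compounds are considered here, and "the series" means these few. Any claim that something is new, unique, unknown or untested is made for them only; others in the source may bear on it.

Compound 1, `Clc1ccc(Nc2cncc(N3CC4CC(C3)N4)c2)cc1`, in an assay on cell membranes for displacement of a labelled ligand from Neuronal acetylcholine receptor; alpha4/beta2 (Rattus norvegicus) (a lower number here means a stronger inhibitor, a higher number a weaker inhibitor), gives 0.118 nM.
Compound 2, `Clc1ccc(Nc2cncc(N3CC4CC(C3)N4)c2)cc1Cl`, gives 1.25 nM.
Compound 3, `Fc1ccc(Nc2cncc(N3CC4CC(C3)N4)c2)cc1`, gives 0.091 nM.

Compound 3 shows the lowest of the three numbers, but the step of a 1.3-fold lower number from compound 1 to compound 3 (0.11 log units; within the scatter) is small and within the scatter, so compound 3 and compound 1 cannot be ordered. Compound 4, `Clc1cccc(Nc2cncc(N3CC4CC(C3)N4)c2)c1`, differs from compound 3 by 3-chlorophenyl in place of 4-fluorophenyl on a nitrogen on an aromatic ring. Among the measured compounds shown here, two measured steps bear on this. The step of a 1.3-fold lower number from compound 1 to compound 3 (0.11 log units; within the scatter) shows that exchanging chlorine for fluorine at one place barely changes the number. The step of an 11-fold higher number from compound 1 to compound 2 (1.03 log units; beyond the scatter) shows that adding a second chlorine weakens binding strongly. For the measured compounds named here, no measured step moves a single chlorine alone, so the outcome is uncertain; a modest weakening is expected, a 3.8-fold higher number from compound 3 to compound 4 (0.59 log units; beyond the scatter). Compound 4 is estimated at 0.35 nM, between 0.08 nM and 1.5 nM.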

Compound 4, inhibition constant: 0.124 nM
For compound 4 the middle estimate is 2.8-fold (0.45 log units) above the measured one; measured number inside the range.
By their numbers in this assay, from the lowest: compounds 3, 1 and 4 (each within the scatter of the next); then compound 2.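

In this assay, 3-chlorophenyl and 4-chlorophenyl on the nitrogen give numbers within the scatter of each other (a 1.1-fold higher number from compound 1 to compound 4 (0.02 log units; within the scatter)), so the place of a single chlorine on this ring does not show up in the binding number. The same holds for 3-chlorophenyl and 4-fluorophenyl (a 1.4-fold higher number from compound 3 to compound 4 (0.13 log units; within the scatter)), while compound 2, with its two chlorines, stands apart (a 10-fold lower number from compound 2 to compound 4 (1.00 log units; beyond the scatter)). Nothing here explains why two chlorines read so differently from one.

Going by these compounds, whether a methoxy group, a nitrile or an amine on this ring would fit the same pattern remains open. So does the reading for 3-fluorophenyl.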